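The compounds below may be only part of what the source reports. "The series", "measured", "known", "first", "only" and "open" are said of these compounds alone.

Compound 1 `COc1ccccc1NC(=S)N/N=C/c1ccc2ccccc2n1`: > 100000 nM, a limit of the assay
Compound 2 `Cc1cccc(NC(=S)N/N=C/c2ccc3ccccc3n2)c1`: > 100000 nM, a limit of the assay

In a functional assay on HeLa cells (Homo sapiens) for antiproliferative activity, read by sulforhodamine B assay, with a stated time of 72 h (on this read-out higher numbers stand for weaker inhibition and lower numbers for stronger inhibition), compound 2 gives > 100000 nM, which is a limit of the assay and not a number. Compound 1 likewise stands at a limit, > 100000 nM. Within the data shown here, both values sit at the limit of > 100000 nM in this assay, at which 2 of the 2 values shown sit, so the single measured step, a step that the two limits leave unreadable from compound 1 to compound 2, has no readable size. Compound 3 `N#Cc1ccc(NC(=S)N/N=C/c2ccc3ccccc3n2)cc1` differs from compound 2 by 4-cyanophenyl in place of 3-methylphenyl on an amide-type nitrogen. Among the measured compounds shown here, no measured step with a readable size bears on this change. Compound 3 is therefore expected to stay at the limit as well, with an expected step of a number no higher from compound 2 to compound 3 (the limit leaves the size open) in this assay. The estimate for compound 3 is 100000 nM, between 50000 nM and 200000 nM.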

Compound 3, half-maximal inhibitory concentration: 20000 nM
Beside the measured number, compound 3's estimate is 5.0-fold (0.70 log units) above it; measured number outside the range, below it.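

In this assay the group on the amide-type nitrogen turns out to matter, with 4-cyanophenyl giving an at least 5.0-fold lower number from compound 2 to compound 3 (0.69 log units; beyond the scatter) and an at least 5.0-fold lower number from compound 1 to compound 3 (0.69 log units; beyond the scatter). Compound 3 is the only one of the three with a readable number, so a change at this place can move the read-out. Both steps have only a minimum size, with compound 1 and compound 2 each at a limit: the limit of > 100000 nM in this assay, at which 2 of the 3 values shown sit.

Whether the nitrile or its ring position accounts for the change stays open. So does the outcome with 3-cyanophenyl, or with a phenyl group bearing an amine or a carboxylic acid.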